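A small ring swap on a carbonyl carbon

The compounds below may be only part of what the source reports. "The series", "measured", "known", "first", "only" and "open" are said of these compounds alone.

Only two results so far frame this question. In an ADME assay on microsomes from liver (Rattus norvegicus) for pharmacokinetics (on this read-out higher numbers stand for fast clearance and lower numbers for slow clearance), compound 1 `Cn1cc(-c2ncc(C#N)c(N3C[C@@H]4C[C@H]3CN4S(=O)(=O)C3CC3)n2)cn1` gives < 36 mL/min/kg as its result, which is a limit of the assay and not a number. Within the data shown here, compound 2 `C[C@@H]1C[C@H]1C(=O)N1CCN(c2nc(-c3cnn(C)c3)ncc2C#N)C[C@H]1C` gives 54 mL/min/kg as the only true number in hand, and that makes it the single firm reference point.

Compound 3 `C[C@@H]1CN(c2nc(-c3cnn(C)c3)ncc2C#N)CCN1C(=O)C1CCC1` has not yet been measured. It holds the same atoms as compound 2, joined differently, with cyclobutyl in place of 2-methylcyclopropyl on a carbonyl carbon and the rest of the molecule unchanged.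

Among the measured compounds shown here, no measured pair in this small set shows what such a swap does, and that leaves only a rough judgement. Both groups are carbon-only rings with the same count of heavy atoms, and compound 2 at 54 mL/min/kg is the natural starting point for the expectation. The expected move is small, an estimated step of a 1.1-fold lower number from compound 2 to compound 3 (0.03 log units; within the scatter) that stays within the usual scatter of repeated measurements. In this assay compound 3 is estimated at 50 mL/min/kg (expected range 30 mL/min/kg to 90 mL/min/kg).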

Compound 3, clearance: < 36 mL/min/kg
Compound 3 gave a limit, no number; the forecaster's own chance of this, stated with the estimate: 15%; middle value at least 1.3-fold (0.14 log units) from the limit.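

In this assay compound 3 gives < 36 mL/min/kg, which is a limit of the assay and not a number. This is the first pair shown that differs in only one place, and the change from 2-methylcyclopropyl to cyclobutyl gives an at least 1.5-fold lower number from compound 2 to compound 3 (0.17 log units; that floor lies within the scatter), so exchanging one carbon-only ring for another with the same number of heavy atoms does not raise the clearance reading, and the true gap may be small or much larger. The size of the step cannot be narrowed further because the result for compound 3 is a limit: the limit of < 36 mL/min/kg in this assay, at which 2 of the 3 values shown sit.

Still open, from the compounds shown here alone, is how far under that limit the true number for compound 3 lies, which a read-out reaching lower values would be needed to settle. Also open, going by these compounds, is what other groups would give on the same carbonyl carbon, such as an open chain like isopropyl or a four-membered ring containing an oxygen atom, like oxetanyl, and whether either would keep the reading as low as cyclobutyl does.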